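From ethoxy to butoxy on a shared core

A few compounds are considered here, and "the series" means these few. Any claim that something is new, unique, unknown or untested is made for them only; others in the source may bear on it.

In a functional assay on HeLa cells (Homo sapiens) for cytotoxicity, read by WST assay, with a stated time of 48 h (a higher number here means that more compound is needed for the effect, a lower number that less compound is needed), compound 1 `O=C1OC[C@H](Cc2ccccc2)[C@H]1Cc1ccc(Cl)c(Cl)c1` gives 26000 nM as its value. For the measured compounds named here, compound 3 `CCOc1ccccc1C[C@H]1COC(=O)[C@@H]1Cc1ccc(Cl)c(Cl)c1` gives 31000 nM in this assay and stands level with compound 1, the only other number available. For compound 2 `O=C1OC[C@H](Cc2ccccc2O)[C@H]1Cc1ccc(Cl)c(Cl)c1` the record reads "not determined" (no result reported) and offers no comparison.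

Compound 4 `CCCCOc1ccccc1C[C@H]1COC(=O)[C@@H]1Cc1ccc(Cl)c(Cl)c1` departs from compound 3 by a single change: ethyl in place of hydrogen on a saturated chain carbon, two bonds along the chain from an oxygen on an aromatic ring turns ethoxy into butoxy.

Going by the values given here, only one measured step bears on this change. With ethoxy in place of hydrogen on an aromatic carbon, the series shows a 1.2-fold higher number from compound 1 to compound 3 (0.08 log units; within the scatter) in this assay and so no movement beyond the scatter. Among the compounds with values here, that step is an indirect guide, as no measured pair isolates a longer chain on this oxygen. Nothing in the data therefore points to a clear shift in either direction.

The expected change is a 1.1-fold lower number from compound 3 to compound 4 (0.04 log units; within the scatter) and would remain within the scatter of this measurement. For compound 4 the estimated value is 28000 nM in this assay, with an expected range from 13000 nM to 60000 nM as the likely span.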

Compound 4, half-maximal effective concentration: > 100000 nM
Compound 4 ended at the assay's limit; the forecaster's own chance of this, stated with the estimate: 12%; middle value at least 3.5-fold (0.55 log units) from the limit.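

The value of compound 4 is a limit of the assay, not a number: the limit of > 100000 nM in this assay, at which 1 of the 4 values shown sits. In this assay, the change from ethoxy to butoxy gives an at least 3.2-fold higher number from compound 3 to compound 4 (0.50 log units; beyond the scatter), and butoxy measured against hydrogen at the same place gives an at least 3.8-fold higher number from compound 1 to compound 4 (0.58 log units; beyond the scatter). The earlier step, a 1.2-fold higher number from compound 1 to compound 3 (0.08 log units; within the scatter), had shown no movement at this position, whereas these two steps show that it does respond once the chain reaches butoxy, with more compound needed for the effect and the full size of the shift hidden by the limit.

The compounds shown leave open at which chain length the shift sets in, for instance whether propoxy would stand with ethoxy or with butoxy. They also leave open whether an amine or a carboxylic acid at the end of the chain on this oxygen would bring the number back toward that of compound 3, which gives 31000 nM in this assay.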